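Replacing 3-fluorophenyl with 2-methoxyphenyl in compound 2

The source may report more compounds than this note shows. Statements on the series, on what has been measured and on what is new or still open speak of the compounds shown alone.

In a functional assay on MDA-MB-436 cells (Homo sapiens) for antiproliferative activity, read by MTT assay, with a stated time of 48 h (a lower number here means a stronger inhibitor, a higher number a weaker inhibitor), compound 1 `CN1CCN(c2ccc(-c3cc4c(N5CCN(C(=O)Nc6ccccc6)CC5)ncnc4s3)cc2)CC1` gives 7090 nM, and compound 2 `CN1CCN(c2ccc(-c3cc4c(N5CCN(C(=O)Nc6cccc(F)c6)CC5)ncnc4s3)cc2)CC1` gives 18300 nM, the higher and so weaker of the two numbers. Compound 3 `COc1ccccc1NC(=O)N1CCN(c2ncnc3sc(-c4ccc(N5CCN(C)CC5)cc4)cc23)CC1` has 2-methoxyphenyl in place of 3-fluorophenyl on an amide-type nitrogen. For the measured compounds named here, the one measured step, a 2.6-fold higher number from compound 1 to compound 2 (0.41 log units; beyond the scatter), is modest and gives only a rough size, with no firm direction. Compound 1 at 7090 nM is the only lower anchor. The expected change is a 1.8-fold lower number from compound 2 to compound 3 (0.26 log units; within the scatter), no larger than that measured step. For compound 3 the estimate is 10000 nM, with an expected range from 4000 nM to 25000 nM.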

Compound 3, half-maximal inhibitory concentration: 26300 nM
Compound 3: middle estimate off by 2.6-fold (0.42 log units), on the low side, and the stated range ends below it.
By their numbers in this assay, from the lowest: compound 1; then compounds 2 and 3 (each within the scatter of the next).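

The swap from 3-fluorophenyl to 2-methoxyphenyl on the amide-type nitrogen gives a 1.4-fold higher number from compound 2 to compound 3 (0.16 log units; within the scatter), so this assay does not tell these two groups apart. With a 3.7-fold higher number from compound 1 to compound 3 (0.57 log units; beyond the scatter), a second substituted ring joins compound 2 in giving a higher number than the plain phenyl of compound 1. Nothing measured here explains these numbers.

Still open, going by these compounds, is whether any group on this ring, such as an amine or a carboxylic acid, would give a lower number than compound 1. Compound 2 and compound 3 also differ in both the group and its place on the ring, so the two contributions cannot be separated.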